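This account rests on a few compounds, and the source may have more. Where it says the series, first, only, none or still open, it means among the compounds named here.

Compound 1 `CN1CCC2C(CCCC2NC(=O)c2ccccc2)C1` — 101 umol/kg
Compound 2 `CN1CCC2C(CCCC2NC(=O)c2ccc(Cl)cc2Cl)C1` — 88 umol/kg
Compound 3 `CN1CCC2C(CCCC2NC(=O)c2ccc([N+](=O)[O-])cc2)C1` — 95 umol/kg

In a functional assay on the whole organism (heart) with Mus musculus as the target (on this read-out higher numbers stand for an effect only at larger amounts of compound and lower numbers for an effect already at smaller amounts), the three measured compounds lie within the scatter of one another; compound 1 gives 101 umol/kg, and neither compound 2 nor compound 3 moves away from it beyond the scatter. Compound 4 `CN1CCC2C(CCCC2NC(=O)c2cccc(Cl)c2)C1` differs from compound 1 by chloro in place of hydrogen on an aromatic carbon. For the measured compounds named here, one measured step bears on a single substituent entering the ring: a 1.1-fold lower number from compound 1 to compound 3 (0.03 log units; within the scatter), within the scatter. Compound 2, which carries two chlorines, gives 88 umol/kg, again within the scatter of compound 1. Nothing here suggests a change beyond the scatter, so the step of a 1.1-fold lower number from compound 1 to compound 4 (0.03 log units; within the scatter) is expected to stay within it. Compound 4 is therefore estimated at 95 umol/kg, with a range from 60 umol/kg to 150 umol/kg.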

Compound 4, dose for half-maximal effect: 73 umol/kg
Compound 4: the middle estimate sits 1.3-fold (0.11 log units) above what was measured; the measured number falls inside the stated range.
By their numbers in this assay, from the lowest: compounds 4, 2, 3 and 1 (each within the scatter of the next).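

With chloro in place of hydrogen on an aromatic carbon, meta to a large group, this assay gives a 1.4-fold lower number from compound 1 to compound 4 (0.14 log units; within the scatter). For the compounds shown here, this shows that a single chlorine at this position, which the earlier compounds did not carry alone, leaves the number within the scatter. Nothing available accounts for the size or direction of this step.

The compounds shown leave open whether an amine, a carboxylic acid or a methoxy group at this same place would move the number beyond the scatter.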